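The source may report more compounds than this note shows. Statements on the series, on what has been measured and on what is new or still open speak of the compounds shown alone.

Measured so far in a functional assay on HUVEC cells (Homo sapiens) for antiproliferative activity, read by MTT assay, with a stated time of 24 h; on this read-out lower numbers stand for stronger inhibition and higher numbers for weaker inhibition:
Compound 1 `C#CCOc1ccc2c(=O)c(-c3cc(OC)c(OC)cc3OC)coc2c1` gives > 10000 nM, which is a limit of the assay.
Compound 2 `COc1cc(OC)c(-c2coc3cc(OCc4ccc([N+](=O)[O-])cc4)ccc3c2=O)cc1OC` gives > 10000 nM, again a limit.
Compound 3 `COc1cc(OC)c(-c2coc3cc(OCc4ccccc4Cl)ccc3c2=O)cc1OC` gives > 10000 nM, also a limit.

Compound 1 therefore has no number of its own in this assay, only a limit, and the same holds for the other two: the limit of > 10000 nM in this assay, at which 3 of the 3 values shown sit. The change to compound 4 `COc1cc(OC)c(-c2coc3cc(OCc4ccccc4Br)ccc3c2=O)cc1OC` is 2-bromophenyl in place of ethynyl on a saturated chain carbon bound to an oxygen on an aromatic ring. The measured steps that come closest are a step that the two limits leave unreadable from compound 1 to compound 3 and a step that the two limits leave unreadable from compound 1 to compound 2; neither has a readable size, and a step that the two limits leave unreadable from compound 2 to compound 3 is likewise unreadable. The expected step for compound 4 is a step that the limit leaves unreadable from compound 1 to compound 4, that is, no readable change. Compound 4 is expected to give 15000 nM, with a range from 5000 nM to 50000 nM, most likely reported again as a limit.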

Compound 4, half-maximal inhibitory concentration: > 10000 nM
Compound 4: only a limit was reported (the forecaster's own chance of this, stated with the estimate: 85%); the middle value lies beyond the limit too.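

In this assay compound 4 gives only a limit, as do compound 1, compound 2 and compound 3, so no step among these four can be read. The compounds shown leave open whether any group at this place gives a measurable value, and how far these four actually differ.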